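This account rests on a few compounds, and the source may have more. Where it says the series, first, only, none or still open, it means among the compounds named here.

Compound 1 `CN(c1ccc2cc(NC(=O)CCc3ccc(C(F)(F)F)cc3)ccc2n1)C1CCCC1`: 2 nM
Compound 2 `CC1CCN(c2ccc3cc(NC(=O)CCc4ccc(C(F)(F)F)cc4)ccc3n2)C1`: 2 nM
Compound 3 `O=C(CCc1ccc(C(F)(F)F)cc1)Nc1ccc2nc(N3CCCCC3)ccc2c1`: 12 nM

These three compounds share one core and differ only in the amine on an aromatic carbon. In an assay on isolated protein for displacement of a labelled ligand from melanin-concentrating hormone receptor 1 (Homo sapiens) (a lower number here means a stronger inhibitor, a higher number a weaker inhibitor), compound 2 stands level with compound 1 at the digits shown, together the two lowest numbers, while compound 3 sits higher: a 6.0-fold higher number from compound 2 to compound 3 (0.78 log units; beyond the scatter). Compound 4 `O=C(CCc1ccc(C(F)(F)F)cc1)Nc1ccc2nc(N3CC4CCC3C4)ccc2c1` carries the same core; its change is a group of 7 heavy atoms (6 carbon, 1 nitrogen; one five-membered non-aromatic ring of carbon only, one five-membered non-aromatic ring with 1 hetero atom) in place of a group of 6 heavy atoms (5 carbon, 1 nitrogen; one five-membered non-aromatic ring with 1 hetero atom), on an aromatic carbon. Among the measured compounds shown here, two measured steps bear on it: no change at the digits printed from compound 1 to compound 2 (within the scatter), and a 6.0-fold higher number from compound 1 to compound 3 (0.78 log units; beyond the scatter). Swapping 3-methylpyrrolidin-1-yl for cyclopentyl(methyl)amino gave no change, and only piperidin-1-yl brought a modest loss. As the entering group keeps a five-membered ring with one nitrogen, a step within the scatter, or at most a small rise, is expected: a 1.5-fold higher number from compound 2 to compound 4 (0.18 log units; within the scatter). Compound 4 is therefore estimated at 3 nM, between 1 nM and 12 nM.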

Compound 4, half-maximal inhibitory concentration: 1 nM
Beside the measured number, compound 4's estimate is 3.0-fold (0.48 log units) above it; the range from low to high includes it.
By their numbers in this assay, from the lowest: compounds 4, 1 and 2 (each within the scatter of the next); then compound 3.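

In this assay, the amine with two five-membered rings stays within the scatter of the simpler amines at this aromatic carbon, with a 2.0-fold lower number from compound 2 to compound 4 (0.30 log units; within the scatter) and a 2.0-fold lower number from compound 1 to compound 4 (0.30 log units; within the scatter). Set against piperidin-1-yl, the same group gives a 12-fold lower number from compound 3 to compound 4 (1.08 log units; beyond the scatter), so among these compounds the extra heavy atom does not bring a rise in the number. Nothing available explains this difference. Still open is how this position responds to a morpholin-4-yl ring, or to an azetidin-1-yl ring, which is smaller than any amine shown here.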